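This account rests on a few compounds, and the source may have more. Where it says the series, first, only, none or still open, it means among the compounds named here.

Compound 1 `COc1ccc(/C=C/C(=O)C(=Cc2ccc(N(C)C)cc2)C(=O)/C=C/c2ccc(OC)c(OC)c2)cc1OC`: 2620 nM
Compound 2 `COc1ccc(/C=C/C(=O)C(=Cc2cccc(F)c2)C(=O)/C=C/c2ccc(OC)c(OC)c2)cc1OC`: 580 nM

In a functional assay on A549 cells (Homo sapiens) for inhibition, read by sulforhodamine B assay, with a stated time of 48 h (a higher number here means a weaker inhibitor of growth, a lower number a stronger inhibitor of growth), compound 2 has the lower of the two numbers, at 580 nM. Compound 3 `COc1ccc(/C=C/C(=O)C(=Cc2ccc(O)cc2)C(=O)/C=C/c2ccc(OC)c(OC)c2)cc1OC` keeps the shared core and alters one group: 4-hydroxyphenyl in place of 3-fluorophenyl on a double-bonded chain carbon bound to a double-bonded chain carbon. Going by the values given here, only one measured step bears on this change, the modest 4.5-fold lower number from compound 1 to compound 2 (0.65 log units; beyond the scatter), and it occurs at the same place. Compound 3 carries 4-hydroxyphenyl, which resembles by name the 4-(dimethylamino)phenyl of compound 1, the compound at 2620 nM. A modest move toward a higher number is therefore expected, with an estimated 2.2-fold higher number from compound 2 to compound 3 (0.35 log units; beyond the scatter). For compound 3 the estimated value is 1300 nM, with an expected range of 400 nM to 3500 nM.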

Compound 3, concentration for 50% growth inhibition: 420 nM
Compound 3: middle estimate off by 3.1-fold (0.49 log units), on the high side; the range from low to high includes it.
By their numbers in this assay, from the lowest: compounds 3 and 2 (each within the scatter of the next); then compound 1.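

In this assay the step of a 1.4-fold lower number from compound 2 to compound 3 (0.14 log units; within the scatter) shows that 4-hydroxyphenyl and 3-fluorophenyl cannot be told apart at this position, even though only 4-hydroxyphenyl counts a hydrogen-bond donor and acceptor. The step of a 6.2-fold lower number from compound 1 to compound 3 (0.80 log units; beyond the scatter) shows that the change from dimethylamino to hydroxy on the aromatic carbon is enough to separate compound 3 from compound 1. No measurement here accounts for either result. The compounds shown leave open what a carboxylic acid or a primary amine in place of hydroxy would give on that aromatic carbon.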